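Solubility at low pH across an aminopyridine-type amide series

This account rests on a few compounds, and the source may have more. Where it says the series, first, only, none or still open, it means among the compounds named here.

Measured compounds:
compound 1 `FC(F)(F)c1cccc(-c2nc3cnc(Nc4ncccn4)cc3[nH]2)c1`, 155000 nM
compound 2 `Fc1ccc(-c2nc3cnc(Nc4cc(C(F)(F)F)ccn4)cc3[nH]2)cc1F`, < 5000 nM
compound 3 `Fc1ccc(Nc2cc3[nH]c(-c4ccc(F)c(C(F)(F)F)c4)nc3cn2)nc1`, 13000 nM

In a physicochemical assay for solubility, using the shake flask method, measured as kinetic solubility, with a stated time of 20 h, at pH 2 (a lower number here means a less soluble compound, a higher number a more soluble compound), compound 1 gives 155000 nM, the highest of the two numbers available. Compound 3 gives 13000 nM, a lower value, and the gap to compound 1 lies beyond the scatter. For compound 2 the result < 5000 nM is a limit of this assay, not a number, as noted in the limit of < 5000 nM in this assay, at which 1 of the 3 values shown sits.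

Compound 4 `O=C(O)c1ccc(Nc2cc3[nH]c(-c4cccc(C(F)(F)F)c4)nc3cn2)nc1` departs from compound 1 by 5-carboxypyridin-2-yl in place of pyrimidin-2-yl on a nitrogen on an aromatic ring. Among the compounds with values here, no measured pair shows a change of this kind, so the expectation rests on compound 1 alone. The change from compound 1 to compound 4 is expected to lower the value, a 2.6-fold lower number from compound 1 to compound 4 (0.41 log units; beyond the scatter), a step likely beyond the scatter. Compound 4 is therefore estimated at 60000 nM, within 10000 nM to 200000 nM.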

Compound 4, solubility: < 5000 nM
Compound 4 was reported as a limit; the forecaster's own chance of this, stated with the estimate: 15%; middle value at least 12-fold (1.07 log units) from the limit.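

On a nitrogen on an aromatic ring, 5-carboxypyridin-2-yl in place of pyrimidin-2-yl gives, in this assay, an at least 31-fold lower number from compound 1 to compound 4 (1.49 log units; beyond the scatter), the first step readable at this position. The result for compound 4 is a limit, not a number, so the step has no known upper size: the limit of < 5000 nM in this assay, at which 2 of the 4 values shown sit.

Still open, on these data alone, is whether the step follows the carboxy group or the change of ring. Unsubstituted pyridin-2-yl, or a pyridine ring carrying an amine or a methyl ester, at the same place would separate the two.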